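Trifluoromethylphenyl to Cyanobenzyl on a Shared Core

The source may report more compounds than this note shows. Statements on the series, on what has been measured and on what is new or still open speak of the compounds shown alone.

Compound 1 `COc1cccc(CNCCCNc2ccnc3cc(-c4ccc(C(F)(F)F)cc4)ccc23)c1O` gives 32000 nM in a physicochemical assay for solubility, with a stated time of 18 h, at pH 7.4; on this read-out higher numbers stand for higher solubility and lower numbers for lower solubility. It stands level with compound 3 `FC(F)(F)c1ccc(-c2ccc3c(NCCCNCc4ccco4)ccnc3c2)cc1`, which gives 32000 nM, the two together the highest of the three numbers, while compound 2 `CC(C)(C)c1ccc(Oc2ccc3c(NCCCNCc4ccco4)ccnc3c2)cc1` gives 14500 nM, a lower number beyond the scatter. Among the compounds with values here, the only measured step between neighbours, no change at the digits printed from compound 1 to compound 3 (within the scatter), concerns the saturated chain carbon bound to an amine nitrogen, not the aromatic carbon changed here. Compound 4 `COc1cccc(CNCCCNc2ccnc3cc(Cc4ccc(C#N)cc4)ccc23)c1O` differs from compound 1 by 4-cyanobenzyl in place of 4-(trifluoromethyl)phenyl on an aromatic carbon. Within the data shown here, no measured step bears on this position, so compound 1 alone serves as anchor, and a step of about a 1.3-fold higher number from compound 1 to compound 4 (0.10 log units; within the scatter) is expected, at most a modest rise. Compound 4 is therefore estimated at 40000 nM, within 14000 nM to 115000 nM.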

Compound 4, solubility: 4200 nM
Compound 4: the middle estimate sits 9.5-fold (0.98 log units) above what was measured; measured number outside the range, below it.
By their numbers in this assay, from the lowest: compound 4; then compound 2; then compounds 1 and 3 (each within the scatter of the next).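

At this aromatic carbon the swap is far from silent in this assay: 4-cyanobenzyl in place of 4-(trifluoromethyl)phenyl gives a 7.6-fold lower number from compound 1 to compound 4 (0.88 log units; beyond the scatter), whereas the earlier step on the saturated chain carbon, no change at the digits printed from compound 1 to compound 3 (within the scatter), showed no such movement. Within the data shown here, the single step changes both the group's link to the shared core and its ring substituent, so it cannot be divided between the two. Nothing shown accounts for the drop. Open, going by these compounds, is which of the two changes carries the step, and how 4-cyanophenyl or 4-(trifluoromethyl)benzyl would read. Also open, on these data alone, is how an amine or a carboxylic acid at this position would compare.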